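The compounds below may be only part of what the source reports. "The series", "measured", "known", "first", "only" and "open" are said of these compounds alone.

Measured in a functional assay on A549 cells (Homo sapiens) for antiproliferative activity, read by MTT assay, with a stated time of 48 h; a lower number here means a stronger inhibitor, a higher number a weaker inhibitor:
- compound 1 `CCCC(C)Oc1ccc(C(=O)/C=C/c2c(/C=C/c3ccc(OC)cc3)cc(OC)cc2OC)cc1`: 9.4 ug/mL
- compound 2 `CCCCCCOc1ccc(C(=O)/C=C/c2c(/C=C/c3ccc(OC)cc3)cc(OC)cc2OC)cc1`: 8.4 ug/mL
- compound 3 `COc1ccc(/C=C/c2cc(OC)cc(OC)c2/C=C/C(=O)c2ccc(Br)cc2)cc1`: 8.3 ug/mL

Compound 3 cannot be separated from the other two compounds, since its value lies within the scatter of both. The next compound to be tested, compound 4 `COc1ccc(/C=C/c2cc(OC)cc(OC)c2/C=C/C(=O)c2ccc(Cl)cc2)cc1`, has chloro in place of bromo on an aromatic carbon, para to a large group: chloro in place of bromo on an aromatic carbon.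

For the measured compounds named here, no measured step makes this exact exchange. The nearest evidence comes from two steps that change the group at the same place: a 1.1-fold lower number from compound 1 to compound 3 (0.05 log units; within the scatter) and a 1.0-fold lower number from compound 2 to compound 3 (0.01 log units; within the scatter). Both lie within the scatter. The remaining step, a 1.1-fold lower number from compound 1 to compound 2 (0.05 log units; within the scatter), changes only the chain on the oxygen and also lies within the scatter.

All three measured compounds thus give closely similar values, although the group at this place differs among them. Taking compound 3 at 8.3 ug/mL as the anchor, no step beyond the scatter is expected in this assay. The expected change is a 1.0-fold higher number from compound 3 to compound 4 (0.01 log units; within the scatter), which would be too small to distinguish from the scatter. Compound 4 is estimated at 8.5 ug/mL, with an expected range from 5.5 ug/mL to 13 ug/mL.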

Compound 4, half-maximal inhibitory concentration: 6.4 ug/mL
For compound 4 the middle estimate is 1.3-fold (0.12 log units) above the measured one; measured number inside the range.
By their numbers in this assay, from the lowest: compounds 4, 3, 2 and 1 (each within the scatter of the next).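

In this assay, the exchange of bromo for chloro on an aromatic carbon, para to a large group, now has a direct reading of its own, a 1.3-fold lower number from compound 3 to compound 4 (0.11 log units; within the scatter), so the two halogens cannot be told apart at this position. Chloro also cannot be separated from either ether chain, with a 1.3-fold lower number from compound 2 to compound 4 (0.12 log units; within the scatter) for the exchange with hexyloxy and a 1.5-fold lower number from compound 1 to compound 4 (0.17 log units; within the scatter) for the exchange with 1-methylbutoxy, and so all four groups seen at this place, two halogens and two chains on an oxygen, lie within the scatter of one another in this assay. Nothing available here bears on why these groups read alike.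

On these data alone, what an amine, a carboxylic acid or a nitrile at this place would give remains open, as does whether any group there can move the number beyond the scatter. Because the rest of the shared core stays the same across all four compounds, the compounds shown also leave open what a change to its methoxy groups, such as a hydroxy in place of one of them, would do.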